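A few compounds are considered here, and "the series" means these few. Any claim that something is new, unique, unknown or untested is made for them only; others in the source may bear on it.

In a functional assay on MDA-MB-231 cells (Homo sapiens) for cytotoxicity, read by MTT assay (on this read-out lower numbers stand for stronger inhibition and higher numbers for weaker inhibition), compound 1 (`COc1ccc(-n2cc(-c3ccc(OC)c(OC)c3)nn2)cc1O`) gives > 1000 nM, which is a limit and not a number. Compound 2 (`COc1ccc(-n2cc(-c3ccc(O)c(OC)c3)nn2)cc1O`) gives > 10000 nM, which is also a limit. Among the compounds with values here, compound 1 therefore has no exact position, and the only other value offers no exact comparison.

Compound 3 (`COc1ccc(-c2cn(-c3ccc(OC)c(O)c3)nn2)cc1O`) differs from compound 1 by hydrogen in place of methyl on an oxygen on an aromatic ring, or methoxy to hydroxy. Within the data shown here, the methyl lost is not the one lost in compound 2. Among the measured compounds shown here, the one measured step of this kind is a step that the two limits leave unreadable from compound 1 to compound 2, so it supplies no size to carry over. No definite step size is expected in this assay, although the direction expected is toward weaker inhibition, if any change appears. Compound 3 is expected near 5000 nM, with an estimated range of 1000 nM to 30000 nM. The expected step is a step that the limit leaves unreadable from compound 1 to compound 3, estimated against a limit.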

Compound 3, half-maximal inhibitory concentration: > 10000 nM
Compound 3 ended at the assay's limit; the forecaster's own chance of this, stated with the estimate: 60%; at least 2.0-fold (0.30 log units) between middle value and limit.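

Compound 1 and compound 3 both carry limits and not numbers, and the step between them cannot be read. The compounds shown leave open whether hydroxy in place of methoxy changes inhibition at all, and by how much, wherever it stands on the shared core.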